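Cyano to fluoro exchange on two related cores

The compounds below may be only part of what the source reports. "The series", "measured", "known", "first", "only" and "open" are said of these compounds alone.

The series holds compound 1 `CC1(C)O[C@H]2O[C@H](Cn3cc(CN4C(=O)/C(=N\Nc5ccc(C#N)cc5)c5ccccc54)nn3)[C@H](O)[C@H]2O1`, compound 2 `CC1(C)O[C@H]2O[C@H](Cn3cc(CN4C(=O)/C(=N\Nc5ccc(F)cc5)c5ccccc54)nn3)[C@H](O)[C@H]2O1`, compound 3 `N#Cc1ccc(N/N=C2\C(=O)N(Cc3cn(O[C@@H]4O[C@H](CO)[C@H](O)[C@H](O)[C@H]4O)nn3)c3ccccc32)cc1` and the unmeasured compound 4 `O=C1/C(=N\Nc2ccc(F)cc2)c2ccccc2N1Cc1cn(O[C@@H]2O[C@H](CO)[C@H](O)[C@H](O)[C@H]2O)nn1`. In an ADME assay on Vero cells (Chlorocebus sabaeus) for cytotoxicity, read by fluorescence and resazurin assay, with a stated time of 3 days (a lower number here means that less compound is tolerated, a higher number that more compound is tolerated), compound 1 gives 105000 nM, compound 2 gives 83800 nM and compound 3 gives 93700 nM. Compound 1 and compound 2 differ by fluoro in place of cyano on an aromatic carbon, which made a step of a 1.3-fold lower number from compound 1 to compound 2 (0.10 log units; within the scatter). The two cores differ by a group of 12 heavy atoms (6 carbon, 6 oxygen; one six-membered non-aromatic ring with 1 hetero atom) in place of a group of 12 heavy atoms (8 carbon, 4 oxygen; one five-membered non-aromatic ring with 1 hetero atom, one five-membered non-aromatic ring with 2 hetero atoms), on an aromatic nitrogen, which made a step of a 1.1-fold lower number from compound 1 to compound 3 (0.05 log units; within the scatter). Compound 3 and compound 4 differ by fluoro in place of cyano on an aromatic carbon, the same change at the same place as between compound 1 and compound 2. For compound 4 a step of a 1.2-fold lower number from compound 3 to compound 4 (0.10 log units; within the scatter) is expected in this assay. This rests on compound 2, whose 83800 nM sits within the scatter of compound 1, and on the cores themselves differing only by a 1.1-fold lower number from compound 1 to compound 3 (0.05 log units; within the scatter). The estimate for compound 4 is 75000 nM, ranging from 40000 nM to 140000 nM.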

Compound 4, half-maximal cytotoxic concentration: 92100 nM
Compound 4: middle estimate off by 1.2-fold (0.09 log units), on the low side, within the range that was stated.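

Fluoro in place of cyano gives a 1.0-fold lower number from compound 3 to compound 4 (0.01 log units; within the scatter) in this assay, and this step shows no readable difference from the earlier one on the other core: the same change on two cores in this assay, a 1.3-fold lower number (0.10 log units; within the scatter) from compound 1 to compound 2 and a 1.0-fold lower number (0.01 log units; within the scatter) from compound 3 to compound 4, 1.2-fold (0.09 log units) apart, within the scatter of two such steps

Exchanging the group on the aromatic nitrogen gives a 1.1-fold higher number from compound 2 to compound 4 (0.04 log units; within the scatter), again with no readable difference: the same change on two cores in this assay, a 1.1-fold lower number (0.05 log units; within the scatter) from compound 1 to compound 3 and a 1.1-fold higher number (0.04 log units; within the scatter) from compound 2 to compound 4, 1.2-fold (0.09 log units) apart, within the scatter of two such steps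

Within the data shown here, since every step here lies within the scatter, the series shows only that neither change moved this read-out on either core; it does not show that a step large enough to read would carry over from one core to the other, or that the same would hold on any further core.

Still open, going by these compounds, is whether an amine, a carboxylic acid or a longer chain in place of cyano or fluoro would give a step beyond the scatter in this assay. Also open, on these data alone, is whether such a step would keep its size on both cores.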